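This account rests on a few compounds, and the source may have more. Where it says the series, first, only, none or still open, it means among the compounds named here.

Series notes on the arylalkynyl phenoxyacetic acids. Compound 1 `CS(=O)(=O)Cc1cccc(C#Cc2cc(Cl)ccc2OCC(=O)O)c1` gives 48 nM in an assay on CHO cells for displacement of a labelled ligand from prostaglandin D2 receptor 2 (Homo sapiens), read by scintillation counting; a lower number here means a stronger inhibitor, a higher number a weaker inhibitor. Compound 3 `CS(=O)(=O)c1cccc(C#Cc2cc(Cl)ccc2OCC(=O)O)c1` gives 15 nM, the change being a 3.2-fold lower number from compound 1 to compound 3 (0.51 log units; beyond the scatter). Within the data shown here, compound 2 `Cc1ccc(S(=O)(=O)NC(C)C)cc1C#Cc1cc(Cl)ccc1OCC(=O)O` gives 3.4 nM and is the strongest of the three, its gaps to compound 3 and to compound 1 both lying beyond the scatter; compound 2 differs from compound 3 in more than one place, so no single step is read between them.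

Compound 4 `CCS(=O)(=O)c1ccc(C)c(C#Cc2cc(Cl)ccc2OCC(=O)O)c1` is the next to be measured. Its change from compound 2 is ethyl in place of isopropylamino on a sulfonyl sulfur. Among the measured compounds shown here, no measured step touches the sulfonyl sulfur itself; the only step in hand, a 3.2-fold lower number from compound 1 to compound 3 (0.51 log units; beyond the scatter), moves the sulfonyl relative to the aromatic carbon and does not bear directly on this exchange. What is known is that compound 2 gives 3.4 nM while compound 3, with methylsulfonyl and no isopropylamino, gives 15 nM, so some loss is expected on leaving isopropylamino. The step expected here reads a 2.1-fold higher number from compound 2 to compound 4 (0.31 log units; beyond the scatter). For compound 4 the estimate in this assay is 7 nM, with a range from 2.5 nM to 20 nM.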

Compound 4, inhibition constant: 8.6 nM
Estimate against measurement, compound 4: 1.2-fold (0.09 log units) below, within the range that was stated.
By their numbers in this assay, from the lowest: compound 2; then compounds 4 and 3 (each within the scatter of the next); then compound 1.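

In this assay, the exchange of isopropylamino for ethyl on the sulfonyl sulfur gives a 2.5-fold higher number from compound 2 to compound 4 (0.40 log units; beyond the scatter), the first step read at this position. The loss is modest: compound 4 stays at 8.6 nM without the nitrogen and the hydrogen-bond donor of isopropylamino, so neither is required for binding at this level in the series. No measurement available here accounts for the direction or size of this step.

The step changes the nitrogen and the size of the group together, so the two cannot be read apart. As far as these compounds go, an isopropyl group or an ethylamino group on the sulfonyl sulfur would separate them, and how either would compare with compound 2 and compound 4 remains open.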